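The source may hold more compounds than are shown below. What is called first, only, known or untested is meant among the compounds shown, and "the series" means these compounds.

Measured so far in a functional assay on MDA-MB-231 cells (Homo sapiens) for antiproliferative activity, read by MTT assay, with a stated time of 24 h; on this read-out lower numbers stand for stronger inhibition and higher numbers for weaker inhibition:

Compound 1 `CCCCOc1ccc(C(=O)NNC(=O)c2ccc(NS(=O)(=O)c3cnc(O)nc3O)cc2)cc1`: 11900 nM
Compound 2 `Cc1ccccc1C(=O)NNC(=O)c1ccc(NS(=O)(=O)c2cnc(O)nc2O)cc1`: 7040 nM
Compound 3 `CCCCOc1ccc(C(=O)NNC(=O)c2cccc(NS(=O)(=O)c3cnc(O)nc3O)c2)cc1`: 17000 nM

Compound 1 and compound 2 share one core and differ in a single place, (2-methylphenyl in place of 4-butoxyphenyl on a carbonyl carbon). The step of a 1.7-fold lower number from compound 1 to compound 2 (0.23 log units; within the scatter) is small and lies within the scatter, so the two values cannot be ordered with confidence. Compound 3 has the same atoms as compound 1 joined differently; the difference between the two cores is not broken down here. Compound 3 sits at the high end of the three numbers, within the scatter of compound 1 and beyond the scatter of compound 2.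

Compound 4 `Cc1ccccc1C(=O)NNC(=O)c1cccc(NS(=O)(=O)c2cnc(O)nc2O)c1` is not yet measured. It carries the core of compound 3 with the change (2-methylphenyl in place of 4-butoxyphenyl on a carbonyl carbon), the same change as between compound 1 and compound 2, at a place described in identical words. Among the compounds with values here, the only precedent is the step from compound 1 to compound 2, which was small. Within the data shown here, for compound 4 in this assay a step of about a 1.7-fold lower number from compound 3 to compound 4 (0.23 log units; within the scatter) is therefore expected, resting on the single precedent a 1.7-fold lower number from compound 1 to compound 2 (0.23 log units; within the scatter) and on the value of compound 3 17000 nM as starting point. Because that precedent step a 1.7-fold lower number from compound 1 to compound 2 (0.23 log units; within the scatter) is within the scatter, the expected movement is modest and uncertain in direction. The estimate for compound 4 is 10000 nM, with a range from 5000 nM to 20000 nM.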

Compound 4, half-maximal inhibitory concentration: 18100 nM
The estimate for compound 4 lay 1.8-fold (0.26 log units) below the measured number, and the stated range covers the measured number.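

In this assay, 2-methylphenyl in place of 4-butoxyphenyl on a carbonyl carbon gives a 1.1-fold higher number from compound 3 to compound 4 (0.03 log units; within the scatter), so this step, like the earlier one, cannot be read as a real movement. Set side by side, the two steps do not differ by more than their combined scatter: the same change on two cores in this assay, a 1.7-fold lower number (0.23 log units; within the scatter) from compound 1 to compound 2 and a 1.1-fold higher number (0.03 log units; within the scatter) from compound 3 to compound 4, 1.8-fold (0.26 log units) apart, within the scatter of two such steps This shows that the change behaves alike on both cores as far as this assay can tell, with neither step resolved from noise and no sign that the core alters its outcome, but it does not show that a real effect of the change carries from one core to the other, as there is no effect here large enough to follow, and two pairs are a thin basis for any rule about the series.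

Still open, on these data alone, is whether a group of another kind on the same carbonyl carbon, such as an amine, a carboxylic acid or a longer alkoxy chain on the phenyl ring, would give a step beyond the scatter. If one did, it would remain to be seen whether that step kept its size and direction on both cores, which would be the first real test of transfer in this series.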